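The source may hold more compounds than are shown below. What is called first, only, known or untested is meant among the compounds shown, and "the series" means these compounds.

Values in a functional assay on Urethra with Alpha-1A adrenergic receptor (Oryctolagus cuniculus) as the target (a lower number here means a smaller maximal response, a higher number a larger maximal response), for the measured compounds:

compound 1 `CS(=O)(=O)Nc1cccc2c1CCCCC2c1c[nH]cn1`: 17%
compound 2 `CC(=O)Nc1cccc2c1CCCC2c1c[nH]cn1`: 70%
compound 3 `CN(c1cccc2c1CCCC2c1c[nH]cn1)S(C)(=O)=O`: 79%

Compound 3 gives the highest of the three numbers in this assay, but its nearest neighbour compound 2 is within the scatter of it, so the two cannot be ordered. For the measured compounds named here, compound 1 lies far below both; it differs from compound 3 in more than one place, and no single step to it is given.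

Going by the values given here, the one measured step is a number 9 percentage points higher from compound 2 to compound 3 (within the scatter), the change being methyl(methylsulfonyl)amino in place of acetamido on an aromatic carbon; it shows no effect beyond the scatter.

Compound 4 `O=S(=O)(Nc1cccc2c1CCCC2c1c[nH]cn1)C1CC1` is not yet measured. It differs from compound 3 by (cyclopropylsulfonyl)amino in place of methyl(methylsulfonyl)amino on an aromatic carbon. Among the compounds with values here, no measured pair covers this exact change. The step from compound 2 to compound 3 suggests that swapping one substituent of this kind for another at this position leaves the maximal response largely unchanged, but compound 1, which also carries a hydrogen-bond-donating sulfonamide, sits very low on a different core, so the spread of plausible outcomes is wide.

On balance compound 4 is expected to stay near compound 3, with an estimated step of a number 19 percentage points lower from compound 3 to compound 4 (beyond the scatter). The estimate for compound 4 is 60%, with a range from 25% to 85%.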

Compound 4, largest response reached (reported as efficacy), in percent of the reference or control that the assay uses: 51%
Estimate against measurement, compound 4: 9 percentage points above; the measured number falls inside the stated range.
By their numbers in this assay, from the lowest: compound 1; then compound 4; then compounds 2 and 3 (each within the scatter of the next).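

On an aromatic carbon of the shared core, this place now shows a change that counts in this assay: the earlier step there stayed within the scatter, whereas (cyclopropylsulfonyl)amino in place of methyl(methylsulfonyl)amino gives a number 28 percentage points lower from compound 3 to compound 4 (beyond the scatter) and so moves the maximal response. Cyclopropylsulfonyl in place of acetyl on the nitrogen gives a number 19 percentage points lower from compound 2 to compound 4 (beyond the scatter) as well, which sets compound 4 apart from both compound 2 and compound 3, two compounds that cannot be ordered against each other. The step to compound 4 brings in a hydrogen-bond donor and a three-membered ring of carbon only together, and no measurement at hand says what lies behind the lower response.

Still open, going by these compounds, is whether the nitrogen methyl or the cyclopropyl carries the step, a question that a methylsulfonylamino or ethylsulfonylamino group on the shared core would separate. Also open, on these data alone, is how a free amine would behave at this place, and how compound 1 at 17% relates to the series, as it differs from the others in more than one place and cannot be compared with them directly.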